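From Ethoxycarbonyl to Methoxycarbonyl: A One-Carbon Trim

The compounds below may be only part of what the source reports. "The series", "measured", "known", "first", "only" and "open" are said of these compounds alone.

For the measured compounds named here, compound 2 `CCOC(=O)N1C[C@@H](C)N(c2ncc3[nH]nc(-c4ccc(N5CCN[C@H](C)C5)nc4)c3n2)[C@@H](C)C1` is one of only two compounds measured in an assay on Sf9 cells for inhibition of activin receptor type-1 (Homo sapiens), read by HTRF, with a stated time of 3 h, in the presence of a further agent that is not named here (a higher number here means a weaker inhibitor, a lower number a stronger inhibitor), and in that assay compound 2 gives 4.9 nM. Compound 1 `CC(C)C(=O)N1C[C@@H](C)N(c2ncc3[nH]nc(-c4ccc(N5CCN[C@H](C)C5)nc4)c3n2)[C@@H](C)C1` gives 8 nM in this assay. Going by the values given here, the one recorded step, a 1.6-fold lower number from compound 1 to compound 2 (0.21 log units; within the scatter), lies within the scatter, so the two numbers cannot be ranked against each other. Compound 3 `COC(=O)N1C[C@@H](C)N(c2ncc3[nH]nc(-c4ccc(N5CCN[C@H](C)C5)nc4)c3n2)[C@@H](C)C1` differs from compound 2 by hydrogen in place of methyl on a saturated chain carbon bound to an oxygen next to a carbonyl group. Among the compounds with values here, no measured step bears directly on this change; the only step available swaps the whole group on the carbonyl carbon, isopropyl for ethoxy, and moves the number very little. Shortening ethyl to methyl is a smaller alteration than that, so for compound 3 no step beyond the scatter is expected. The estimate for compound 3 in this assay is 5 nM, with a range from 2.5 nM to 10 nM, which corresponds to an expected step of a 1.0-fold higher number from compound 2 to compound 3 (0.01 log units; within the scatter).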

Compound 3, half-maximal inhibitory concentration: 0.85 nM
Estimate against measurement, compound 3: 5.9-fold (0.77 log units) above, outside the stated range (below it).
By their numbers in this assay, from the lowest: compound 3; then compounds 2 and 1 (each within the scatter of the next).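

In this assay, trimming ethoxycarbonyl to methoxycarbonyl gives a 5.8-fold lower number from compound 2 to compound 3 (0.76 log units; beyond the scatter), so losing one methyl at this end of the group moves the number beyond the scatter, which the earlier swap of isopropyl for ethoxy did not do. Placing methoxy instead of isopropyl on the carbonyl carbon gives a 9.4-fold lower number from compound 1 to compound 3 (0.97 log units; beyond the scatter), which shows that the group on this carbon can matter and that the smallest of these changes can have a clear effect. No available evidence explains why the shorter chain gives the lower number.

The compounds shown leave open how a longer chain such as propoxy, or a branched isopropoxy group, would read on the same carbonyl carbon. They also leave open whether an amine at that carbon, such as methylamino, would keep the low number seen with methoxy.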